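This account rests on a few compounds, and the source may have more. Where it says the series, first, only, none or still open, it means among the compounds named here.

Measured compounds:
Compound 1 `COc1ccc2nc(NC(c3cn(-c4ccccc4)nc3-c3cccc([N+](=O)[O-])c3)c3c(O)ccc4ccccc34)sc2c1`: 6140 nM
Compound 2 `COc1cccc(-c2nn(-c3ccccc3)cc2C(Nc2nc3ccc(OC)cc3s2)c2c(O)ccc3ccccc23)c1`: 10500 nM
Compound 3 `O=[N+]([O-])c1cccc(-c2nn(-c3ccccc3)cc2C(Nc2nc3ccc(Cl)cc3s2)c2c(O)ccc3ccccc23)c1`: 15500 nM

The three measured compounds were tested in a functional assay on HeLa cells (Homo sapiens) for antiproliferative activity, read by MTT assay, with a stated time of 48 h; on this read-out higher numbers stand for weaker inhibition and lower numbers for stronger inhibition. Compound 1 gives 6140 nM in this assay. Compound 2 differs from compound 1 by methoxy in place of nitro on an aromatic carbon, and the step is a 1.7-fold higher number from compound 1 to compound 2 (0.23 log units; within the scatter). Compound 3 differs from compound 1 by chloro in place of methoxy on an aromatic carbon, and here the step is a 2.5-fold higher number from compound 1 to compound 3 (0.40 log units; beyond the scatter).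

Compound 4 `COc1cccc(-c2nn(-c3ccccc3)cc2C(Nc2nc3ccc(Cl)cc3s2)c2c(O)ccc3ccccc23)c1` has not yet been measured. It differs from compound 3 by methoxy in place of nitro on an aromatic carbon. This is the same change as that from compound 1 to compound 2, on the same place of the ring, but it is now made on the core of compound 3 rather than on the core of compound 1, and how those two cores differ is told by chloro in place of methoxy on an aromatic carbon. Because the earlier step of a 1.7-fold higher number from compound 1 to compound 2 (0.23 log units; within the scatter) was small, the step from compound 3 to compound 4 is expected to be of a similar size, estimated as a 1.5-fold higher number from compound 3 to compound 4 (0.17 log units; within the scatter). The number for compound 4 is thus expected to be about 23000 nM in this assay, estimated to fall between 11000 nM and 48000 nM.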

Compound 4, half-maximal inhibitory concentration: 30000 nM
For compound 4 the middle estimate is 1.3-fold (0.12 log units) below the measured one, and the stated range covers the measured number.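

In this assay, going by these compounds alone, methoxy in place of nitro gives a 1.9-fold higher number from compound 3 to compound 4 (0.29 log units; within the scatter), a step of much the same size as the one seen for this change on the core of compound 1: the same change on two cores in this assay, a 1.7-fold higher number (0.23 log units; within the scatter) from compound 1 to compound 2 and a 1.9-fold higher number (0.29 log units; within the scatter) from compound 3 to compound 4, 1.1-fold (0.05 log units) apart, within the scatter of two such steps. Chloro in place of methoxy gives a 2.9-fold higher number from compound 2 to compound 4 (0.46 log units; beyond the scatter), and this change also carries over from one core to the other: the same change on two cores in this assay, a 2.5-fold higher number (0.40 log units; beyond the scatter) from compound 1 to compound 3 and a 2.9-fold higher number (0.46 log units; beyond the scatter) from compound 2 to compound 4, 1.1-fold (0.05 log units) apart, within the scatter of two such steps. The four compounds thus show the two changes combining without any detectable interaction, but each comparison rests on a single pair of cores, both methoxy-for-nitro steps lie within the scatter, and the data do not explain why either change acts as it does.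

The compounds shown leave open whether this agreement would hold for other groups at the same place of the ring, such as an amine or a carboxylic acid. They also leave open whether it would extend to a core carrying a methyl group or an amine where compounds 3 and 4 carry chloro.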